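The source may hold more compounds than are shown below. What is called first, only, known or untested is meant among the compounds shown, and "the series" means these compounds.

Working notes on the series, read in a physicochemical assay for solubility, read by HPLC, using the shake flask method, in phosphate buffer, with a stated time of 20 h, at pH 6.5; a lower number here means a less soluble compound, a higher number a more soluble compound. Compound 1 (`CN1CCN(C2CCN(c3nccc4[nH]c(-c5ccc(F)c(F)c5)nc34)CC2)CC1`) gives 130000 nM, and compound 2 (`CN1CCN(C2CCN(c3nccc4[nH]c(-c5cccc(OC(F)(F)F)c5)nc34)CC2)CC1`) gives 190000 nM. Among the compounds with values here, these are the only two numbers so far, and compound 2 stands within the scatter of compound 1, so the pair cannot be ranked.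

The next compound is compound 3 (`CN1CCN(C2CCN(c3nccc4[nH]c(-c5ccc(F)c(C(F)(F)F)c5)nc34)CC2)CC1`), which differs from compound 2 in one place: 4-fluoro-3-(trifluoromethyl)phenyl in place of 3-(trifluoromethoxy)phenyl on an aromatic carbon. The change is 4-fluoro-3-(trifluoromethyl)phenyl in place of 3-(trifluoromethoxy)phenyl, on an aromatic carbon of a five-membered aromatic ring with 2 nitrogen, between two ring nitrogen atoms.

Within the data shown here, one measured step bears on this place: a 1.5-fold higher number from compound 1 to compound 2 (0.16 log units; within the scatter), with 3-(trifluoromethoxy)phenyl in place of 3,4-difluorophenyl. That single step stayed within the scatter, and nothing measured yet gives a direction. No step beyond the scatter is therefore expected in this assay for the new change. The expected step, an estimate only, is a 1.3-fold lower number from compound 2 to compound 3 (0.10 log units; within the scatter). For compound 3 the estimated value is 150000 nM, with an expected range of 70000 nM to 300000 nM.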

Compound 3, solubility: 195000 nM
Compound 3: the middle estimate sits 1.3-fold (0.11 log units) below what was measured, and the stated range covers the measured number.
By their numbers in this assay, from the lowest: compounds 1, 2 and 3 (each within the scatter of the next).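

Working notes, this assay: at this aromatic carbon, 4-fluoro-3-(trifluoromethyl)phenyl in place of 3-(trifluoromethoxy)phenyl gives a 1.0-fold higher number from compound 2 to compound 3 (0.01 log units; within the scatter), so an exchange that removes the oxygen and the hydrogen-bond acceptor counted in the leaving group still stays inside the scatter. Trifluoromethyl in place of fluoro on an aromatic carbon of the same aryl group gives a 1.5-fold higher number from compound 1 to compound 3 (0.18 log units; within the scatter), so compounds 1, 2 and 3 now form a single level with no order among them, and two further changes at this place join the first in showing no step beyond the scatter. No supporting measurement that bears on this flat reading is at hand.

All three groups at this place are fluorinated phenyl rings on an unchanged remainder of the molecule, so the reading covers only that narrow set. From the compounds shown here alone, whether a phenyl carrying a carboxylic acid or an amine at this place would give a step beyond the scatter stays open, as does the effect of any change elsewhere in the shared core.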